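The source may report more compounds than this note shows. Statements on the series, on what has been measured and on what is new or still open speak of the compounds shown alone.

Within the data shown here, in a functional assay on PC-3 cells (Homo sapiens) for cytotoxicity, read by MTT assay (a higher number here means a weaker inhibitor, a lower number a stronger inhibitor), compound 1 `COc1ccc2cc([C@H](C)c3nnc(SCc4c(C)cc(C)cc4C)n3-c3cccc(Cl)c3)ccc2c1` gives 16300 nM, the lowest number so far. Compound 2 `COc1cccc(CSc2nnc([C@@H](C)c3ccc4cc(OC)ccc4c3)n2-c2ccc(Cl)cc2)c1` gives 138000 nM, a gap beyond the scatter. Compound 3 `COc1ccc2cc([C@H](C)c3nnc(SCc4ccc(F)cc4)n3-c3ccc(F)cc3)ccc2c1` reads <= 400000 nM, which is a limit of the assay and not a number. Compound 4 `COc1ccc2cc([C@H](C)c3nnc(SCc4c(Cl)cccc4Cl)n3-c3cccc(Cl)c3)ccc2c1` departs from compound 1 in one place, on a saturated chain carbon bound to a sulfur: 2,6-dichlorophenyl in place of 2,4,6-trimethylphenyl (2,6-dichlorophenyl in place of 2,4,6-trimethylphenyl on a saturated chain carbon bound to a sulfur). Among the measured compounds shown here, no measured step covers this change, so the only guide is the spread from compound 1 at 16300 nM to compound 2 at 138000 nM. The expected step is a 2.5-fold higher number from compound 1 to compound 4 (0.39 log units; beyond the scatter), a moderate move towards a higher number. For compound 4 the estimated value is 40000 nM, with an expected range of 10000 nM to 180000 nM.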

Compound 4, half-maximal inhibitory concentration: 165000 nM
Beside the measured number, compound 4's estimate is 4.1-fold (0.62 log units) below it, and the stated range covers the measured number.
By their numbers in this assay, from the lowest: compound 1; then compounds 2 and 4 (each within the scatter of the next).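

In this assay, 2,6-dichlorophenyl in place of 2,4,6-trimethylphenyl on a saturated chain carbon bound to a sulfur gives a 10-fold higher number from compound 1 to compound 4 (1.01 log units; beyond the scatter). This first measured step shows that this position responds strongly to what the aromatic ring carries, since both groups are six-membered aromatic rings of carbon only. One value in the set is a limit and not a number: the limit of <= 400000 nM in this assay, at which 1 of the 4 values shown sits.

Whether the methyl groups or the chlorines account for the step stays open. On these data alone, how a morpholine or a carboxylic acid on this ring would read also stays open.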